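A few compounds are considered here, and "the series" means these few. Any claim that something is new, unique, unknown or untested is made for them only; others in the source may bear on it.

Compound 1, `COc1ccc(Nc2cc(C)oc(=O)c2)cc1`, gives > 30 uM in a functional assay on SK-BR-3 cells (Homo sapiens) for cytotoxicity, read by MTT assay, with a stated time of 72 h (a lower number here means that less compound is needed, a higher number that more compound is needed for the effect), which is a limit of the assay and not a number.
Compound 2, `COc1ccc(Nc2cc(/C=C/c3ccccc3)oc(=O)c2)cc1`, gives 0.083 uM in this assay.
Compound 3, `COc1ccc(Nc2cc(-c3ccccc3)oc(=O)c2)cc1`, gives 0.079 uM in this assay.

Of the two numbers, compound 3 has the lowest, with compound 2 nearest; the step of a 1.1-fold lower number from compound 2 to compound 3 (0.02 log units; within the scatter) lies within the scatter, so the two cannot be told apart. Compound 4, `COc1ccc(Nc2cc(C3CCCC3)oc(=O)c2)cc1`, has not been measured. It differs from compound 3 in one place: cyclopentyl in place of phenyl on an aromatic carbon. For the measured compounds named here, two measured steps bear on this position. Phenyl in place of methyl gave an at least 370-fold lower number from compound 1 to compound 3 (2.57 log units; beyond the scatter), and 2-phenylethenyl in place of methyl gave an at least 360-fold lower number from compound 1 to compound 2 (2.55 log units; beyond the scatter). Compound 1 sits at the limit of > 30 uM in this assay, at which 1 of the 3 values shown sits, so both of those steps are known only as minimum sizes. Going by the values given here, both large gains came with a group built on a six-membered aromatic ring; cyclopentyl brings a five-membered non-aromatic ring, and no measured compound shows what such a group does at this place. The expectation is therefore a weaker compound than compound 3, with wide uncertainty in both directions. Compound 4 is estimated at 3 uM, between 0.3 uM and 30 uM, which is expected to be the step of a 38-fold higher number from compound 3 to compound 4 (1.58 log units; beyond the scatter).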

Compound 4, concentration for half-maximal effect: 4.73 uM
Beside the measured number, compound 4's estimate is 1.6-fold (0.20 log units) below it; low and high end bracket the measured number.
By their numbers in this assay, from the lowest: compounds 3 and 2 (each within the scatter of the next); then compound 4. At a limit, above all of these: compound 1.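

Cyclopentyl in place of methyl on this aromatic carbon, next to the ring oxygen, gives an at least 6.3-fold lower number from compound 1 to compound 4 (0.80 log units; beyond the scatter), so a five-membered non-aromatic ring of carbon only also lowers the number in this assay, and a six-membered aromatic ring is not needed for some gain here. That step is only a minimum size, with compound 1 at a limit of the assay and not a number: the limit of > 30 uM in this assay, at which 1 of the 4 values shown sits. The gain from cyclopentyl still stops well short of the other two groups: cyclopentyl in place of phenyl gives a 60-fold higher number from compound 3 to compound 4 (1.78 log units; beyond the scatter), and cyclopentyl in place of 2-phenylethenyl gives a 57-fold higher number from compound 2 to compound 4 (1.76 log units; beyond the scatter), so at this place the choice of ring carries a large effect on the number.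

Cyclopentyl differs from phenyl both in ring size and in being non-aromatic, so these compounds cannot say which of the two matters, and cyclohexyl or thienyl would be the groups that pull them apart. Also open, on these data alone, is what a ring or chain of another kind would give here, such as pyridyl, an amine or a longer chain like butyl.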